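A Carboxyphenyl Replaces an Imidazole on a Weak Activator

The source may hold more compounds than are shown below. What is called first, only, known or untested is meant among the compounds shown, and "the series" means these compounds.

Going by the values given here, compound 2 `Cn1ccnc1CN1CCC[C@H](OCc2cc(Cl)cc(Cl)c2)[C@@H]1c1ccccc1` is one of two compounds measured in an assay on isolated protein for activation of cGMP-dependent protein kinase 1 (Homo sapiens), read by ADP-Glo, with stated times of 120 min and 40 min; on this read-out higher numbers stand for an effect only at larger amounts of compound and lower numbers for an effect already at smaller amounts; there compound 2 gives 165000 nM. Compound 1 `Clc1cc(Cl)cc(CO[C@H]2CCCN(Cc3cccnc3)[C@H]2c2ccccc2)c1` gives 112000 nM in this assay, so compound 2 carries the larger of the two numbers shown, yet the step of a 1.5-fold higher number from compound 1 to compound 2 (0.17 log units; within the scatter) lies within the scatter, and the two values cannot be told apart. Compound 3 `O=C(O)c1ccc(CN2CCC[C@H](OCc3cc(Cl)cc(Cl)c3)[C@@H]2c2ccccc2)cc1` differs from compound 2 by 4-carboxyphenyl in place of 1-methyl-1H-imidazol-2-yl on a saturated chain carbon bound to an amine nitrogen in a ring. Among the compounds with values here, the only measured step at this place is a 1.5-fold higher number from compound 1 to compound 2 (0.17 log units; within the scatter), which exchanged one aromatic group for another without moving the number beyond the scatter. That step bears on the new change only loosely, since a carboxyphenyl is neither of the groups already tried, so no shift beyond the scatter is expected in either direction. The estimated step is a 1.1-fold lower number from compound 2 to compound 3 (0.04 log units; within the scatter). Compound 3 is therefore expected to give about 150000 nM in this assay, with a range from 50000 nM to 450000 nM.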

Compound 3, half-maximal effective concentration: 76000 nM
Compound 3: the middle estimate sits 2.0-fold (0.30 log units) above what was measured; the range from low to high includes it.
By their numbers in this assay, from the lowest: compounds 3, 1 and 2 (each within the scatter of the next, the first and the last beyond it).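

In this assay, going by these compounds alone, a 2.2-fold lower number from compound 2 to compound 3 (0.34 log units; beyond the scatter) is the first step at this place, on a saturated chain carbon bound to an amine nitrogen in a ring, to pass the scatter, so the group here can move the number, if only modestly. That shift appears only against 1-methyl-1H-imidazol-2-yl: against pyridin-3-yl, a 1.5-fold lower number from compound 1 to compound 3 (0.17 log units; within the scatter) leaves the two compounds indistinguishable. No measurement at hand accounts for the step.

The compounds shown leave open whether the number follows the carboxylic acid or the carbon-only ring that carries it, which a plain phenyl, a methyl ester or a primary amide in its place would address. They also leave open whether a longer chain ending in a carboxylic acid, or an aliphatic amine, would lower the number any further.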